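This account rests on a few compounds, and the source may have more. Where it says the series, first, only, none or still open, it means among the compounds named here.

Compound 1 `COc1ccccc1NCC(=O)Oc1ccc2c(C)cc(=O)oc2c1` stands lowest of the three compounds measured in a functional assay on the whole organism (strain Wistar albino) for inhibition, with Rattus norvegicus as the target, read by paw edema, with stated times of 30 min and 1 h, at a dose of 20 mg/kg by the oral route (on this read-out higher numbers stand for more inhibition at the one dose given (going by the name of the read-out) and lower numbers for less inhibition), where compound 1 gives 10.7%. Compound 2 `Cc1cc(=O)oc2cc(OC(=O)CNc3ccccc3[N+](=O)[O-])ccc12` gives 21.4%, and compound 3 `Cc1cc(=O)oc2cc(OC(=O)CNc3nc4ccccc4s3)ccc12` gives 30.3%. Compound 4 `Cc1cc(=O)oc2cc(OC(=O)CNc3ccc(Cl)cc3)ccc12` differs from compound 1 in one place: 4-chlorophenyl in place of 2-methoxyphenyl on an amine nitrogen. Going by the values given here, the only measured step that bears on a change at this part of the molecule is a number 10.7 percentage points higher from compound 1 to compound 2 (beyond the scatter), a modest gain when the group on the aromatic carbon was exchanged. Among the compounds with values here, compound 3 carries yet another group on the amine nitrogen, but no single-place step links it to compound 1, so its value only suggests that such exchanges tend upward here. Compound 4 is therefore expected to show a modest rise, a number 9.3 percentage points higher from compound 1 to compound 4 (within the scatter), giving an estimated 20% with a likely range from 9% to 32%.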

Compound 4, a percentage reported as inhibition, in the whole organism at one dose (the size of the read-out at that dose, not a potency): 10.7%
For compound 4 the middle estimate is 9.3 percentage points above the measured one; the range from low to high includes it.
By their numbers in this assay, from the lowest: compounds 1 and 4 (each within the scatter of the next); then compounds 2 and 3 (each within the scatter of the next).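

In this assay, putting 4-chlorophenyl in place of 2-methoxyphenyl on the amine nitrogen gives no change at the digits printed from compound 1 to compound 4 (within the scatter). So the upward step seen earlier with nitro in place of methoxy does not extend to every exchange at this part of the molecule: this new aromatic group leaves the read-out where it was. Nothing available explains why these two groups read alike.

As far as these compounds go, how a plain phenyl group, or a phenyl group carrying a carboxylic acid, would read on this amine nitrogen stays open.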